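Removing the Ring Methyl From Compound 1

A few compounds are considered here, and "the series" means these few. Any claim that something is new, unique, unknown or untested is made for them only; others in the source may bear on it.

Of the compounds shown here, two have so far been measured in a functional assay, read by spectrophotometry, with a stated time of 5 min; a lower number here means a stronger inhibitor, a higher number a weaker inhibitor. Compound 1 `Cc1ccc2[nH]c(=O)c(/C=N/c3ccccc3O)cc2c1` gives 286000 nM in this assay. Going by the values given here, its single measured neighbour, compound 2 `CCCC/N=C/c1cc2cc(C)ccc2[nH]c1=O`, gives 379000 nM in this assay, and the step of a 1.3-fold higher number from compound 1 to compound 2 (0.12 log units; within the scatter) stays within the scatter, so the two numbers cannot be ordered and compound 1 stands level with compound 2. Compound 3 `O=c1[nH]c2ccccc2cc1/C=N/c1ccccc1O` is still to be measured. It differs from compound 1 by hydrogen in place of methyl on an aromatic carbon. Among the compounds with values here, the only step measured so far concerns the group on the double-bonded nitrogen, not the ring methyl, so it does not bear directly on this change; it shows only that a sizeable alteration elsewhere on the shared core left the number within the scatter. Within the data shown here, no measured step speaks to the ring methyl itself. On this basis no step beyond the scatter is expected in this assay, and the change is expected to amount to a 1.0-fold higher number from compound 1 to compound 3 (0.02 log units; within the scatter). Compound 3 is therefore estimated to give 300000 nM, with a range from 120000 nM to 750000 nM.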

Compound 3, half-maximal inhibitory concentration: 237000 nM
Beside the measured number, compound 3's estimate is 1.3-fold (0.10 log units) above it, within the range that was stated.
By their numbers in this assay, from the lowest: compounds 3, 1 and 2 (each within the scatter of the next).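

In this assay, going by these compounds alone, taking off the methyl gives a 1.2-fold lower number from compound 1 to compound 3 (0.08 log units; within the scatter) and stays within the scatter, which is the first direct reading at this position. The earlier step concerned only the group on the double-bonded nitrogen, whereas this one shows that hydrogen in place of methyl, on the aromatic carbon meta to a fused ring and para to a fused ring, leaves compound 1 and compound 3 level, so the methyl's single carbon makes no difference that can be told apart from repeated measurement in this pair. Nothing available here explains this result or bears on it.

The compounds shown hold only methyl and hydrogen at this aromatic carbon, so it remains open whether a larger or differently charged group there, such as a methoxy group, a chlorine atom, an amine or a carboxylic acid, would carry the number beyond the scatter. On these data alone, it also remains open whether butyl in place of 2-hydroxyphenyl on the double-bonded nitrogen would behave the same way on the core of compound 3, which lacks the methyl.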